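The compounds below may be only part of what the source reports. "The series", "measured", "known", "first", "only" and "open" are said of these compounds alone.

- Compound 1 `BrCCCOc1c(Br)cc(Br)cc1Oc1ccc(Br)cc1Br`: 29.9 ug/mL
- Compound 2 `BrCCCCOc1c(Br)cc(Br)cc1Oc1ccc(Br)cc1Br`: 25.9 ug/mL
- Compound 3 `OCCCOc1c(Br)cc(Br)cc1Oc1ccc(Br)cc1Br`: 29.9 ug/mL

In a functional assay on HL-60 cells (Homo sapiens) for cytotoxicity, read by MTT assay, with a stated time of 24 h (on this read-out higher numbers stand for weaker inhibition and lower numbers for stronger inhibition), compound 3 gives 29.9 ug/mL, level with compound 1, and compound 2 lies within the scatter of both. Compound 4 `CC(=O)Oc1c(Br)cc(Br)cc1Oc1ccc(Br)cc1Br` differs from compound 3 as follows: acetyl in place of 3-hydroxypropyl on an oxygen on an aromatic ring. The nearest evidence is no change at the digits printed from compound 1 to compound 3 (within the scatter), a 1.2-fold lower number from compound 1 to compound 2 (0.06 log units; within the scatter) and a 1.2-fold higher number from compound 2 to compound 3 (0.06 log units; within the scatter). All three stay within the scatter, but each alters only a group on the saturated chain, and none removes the chain. This evidence is therefore indirect, and no step beyond the scatter is expected. The estimated change is a 1.1-fold lower number from compound 3 to compound 4 (0.04 log units; within the scatter). For compound 4, the expected value is 27 ug/mL, with an estimated range of 12 ug/mL to 55 ug/mL.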

Compound 4, half-maximal inhibitory concentration: 29.9 ug/mL
The estimate for compound 4 lay 1.1-fold (0.04 log units) below the measured number, and the stated range covers the measured number.
By their numbers in this assay, from the lowest: compounds 2, 1, 3 and 4 (each within the scatter of the next).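

Replacing the chain on this oxygen with acetyl is the first change shown that removes the chain altogether, yet this assay gives no change at the digits printed from compound 3 to compound 4 (within the scatter) and the number does not move. The comparisons with the two bromo chains agree, showing a 1.2-fold higher number from compound 2 to compound 4 (0.06 log units; within the scatter) and no change at the digits printed from compound 1 to compound 4 (within the scatter) as well, so 3-hydroxypropyl, 3-bromopropyl, 4-bromobutyl and acetyl cannot be told apart at this position. No measurement on hand explains this flat result.

An amine, a carboxylic acid or a much longer chain on this oxygen might behave differently. Also open, going by these compounds, is what a change on the shared core would do.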